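Swapping Methoxy for Phenyl on the Shared Core

The source may hold more compounds than are shown below. What is called first, only, known or untested is meant among the compounds shown, and "the series" means these compounds.

Compound 1, `C=C[C@@](C)(/C=C/c1ccc(OC)cc1)CCC=C(C)C`, was tested in a functional assay on SEM cells (Homo sapiens) for cytotoxicity, with a stated time of 72 h; a higher number here means that more compound is needed for the effect, a lower number that less compound is needed. In this assay compound 1 reaches only the limit of > 36600 nM, so no true number is known for it. Compound 2, `C=C[C@@](C)(/C=C/c1ccc(O)cc1)CC/C=C(C)/C=N/N`, shares the same core but differs elsewhere in its groups. In this assay compound 2 likewise stops at the limit of > 36600 nM. So compound 1 stands at the limit of > 36600 nM in this assay, at which 2 of the 2 values shown sit, and nothing shown here separates it from compound 2.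

Compound 3, `C=C[C@@](C)(/C=C/c1ccc(-c2ccccc2)cc1)CCC=C(C)C`, follows from compound 1 by a single change: phenyl in place of methoxy on an aromatic carbon. Going by the values given here, no measured step between two compounds that differ in one place exists in this set, so no direction can be read from the numbers at hand. With every known value sitting at the limit, the change is expected to bring no shift beyond the usual scatter in this assay, and compound 3 is expected to remain at that limit as well.

Compound 3 is estimated at 40000 nM, within a range from 12000 nM to 150000 nM. The step that the limit leaves unreadable from compound 1 to compound 3 is expected to be essentially flat.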

Compound 3, half-maximal effective concentration: > 36600 nM
Compound 3: only a limit was reported; the forecaster's own chance of this, stated with the estimate: 75%; the middle value does not contradict the limit.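

In this assay compound 3 gives > 36600 nM, which is a limit and not a number. Compound 1 also stands at a limit, so no step can be read between compound 1 and compound 3: the limit of > 36600 nM in this assay, at which 3 of the 3 values shown sit.

The compounds shown leave open how much of each is needed for the effect, and whether phenyl in place of methoxy shifts that amount.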